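A few compounds are considered here, and "the series" means these few. Any claim that something is new, unique, unknown or untested is made for them only; others in the source may bear on it.

Measured so far:
compound 1 `COc1ccc(C2=C(c3cc(OC)c(OC)c(OC)c3)C(=O)C(OC(C)=O)C2)cc1Cl` — < 1 ug/mL
compound 2 `COc1ccc(C2=C(c3cc(OC)c(OC)c(OC)c3)C(=O)C(O[SiH2]C(C)(C)C)C2)cc1OC(C)C` — 7 ug/mL
compound 3 `COc1ccc(C2=C(c3cc(OC)c(OC)c(OC)c3)C(=O)C(OC(C)=O)C2)cc1` — > 100 ug/mL

The read-out is an ADME assay on L132 cells (Homo sapiens) for cytotoxicity, read by MTT assay, with a stated time of 72 h; a higher number here means a weaker inhibitor, a lower number a stronger inhibitor. Compound 1 sits at a limit, (the limit of < 1 ug/mL in this assay, at which 1 of the 3 values shown sits), so its value is a bound, not a number. Compound 3 likewise sits at a limit, (the limit of > 100 ug/mL in this assay, at which 1 of the 3 values shown sits), and so stands at the weak end of what this assay can report. Compound 2, which carries the silyl ether in place of the acetate and an isopropoxy group on the aryl ring, gives 7 ug/mL. For the measured compounds named here, the one step that can be followed between measured compounds is an at least 100-fold higher number from compound 1 to compound 3 (2.00 log units; beyond the scatter), a change on the aromatic ring that has nothing to do with the ester oxygen.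

Compound 4 `COc1ccc(C2=C(c3cc(OC)c(OC)c(OC)c3)C(=O)C(O[SiH2]C(C)(C)C)C2)cc1` is still to be measured in this assay. It differs from compound 3 by a group of 5 heavy atoms (4 carbon, 1 silicon; no ring) in place of a group of 3 heavy atoms (2 carbon, 1 oxygen; no ring), on an oxygen on a saturated carbon. Going by the values given here, no measured step follows this exchange on its own: compound 2 and compound 3 share the same aryl pattern only in part, so their values show at most that a silyl ether can coexist with a numerical value in this assay. The step of an at least 2.0-fold lower number from compound 3 to compound 4 (0.30 log units; that floor lies within the scatter) is therefore an expectation with little support, leaning toward a stronger number because compound 3 stands at the limit of > 100 ug/mL in this assay, at which 1 of the 3 values shown sits, and can only move down. Compound 4 is estimated at 50 ug/mL, within 10 ug/mL to 150 ug/mL.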

Compound 4, half-maximal inhibitory concentration: 9 ug/mL
Compound 4: middle estimate off by 5.6-fold (0.74 log units), on the high side; measured number outside the range, below it.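

In this assay, the oxygen on a saturated carbon is now a place where a single exchange can be followed: putting the silyl group in place of acetyl gives an at least 11-fold lower number from compound 3 to compound 4 (1.04 log units; beyond the scatter). Compound 3 sits at a limit, so this step has a floor and no true size: the limit of > 100 ug/mL in this assay, at which 1 of the 4 values shown sits. With the silyl group on this oxygen, the exchange on the aromatic carbon gives a 1.3-fold higher number from compound 2 to compound 4 (0.11 log units; within the scatter), so the two cannot be told apart in this read-out.

Open, on these data alone, is whether chloro on the aromatic carbon would give a step of similar size with the silyl group on the oxygen as it does with acetyl. Also open, as far as these compounds go, is how this oxygen behaves with a free hydroxyl, a longer acyl chain or a chain ending in an amine.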